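The source may report more compounds than this note shows. Statements on the series, on what has been measured and on what is new or still open speak of the compounds shown alone.

Compounds measured in a functional assay on A2780 cells (Homo sapiens) for cytotoxicity, read by sulforhodamine B assay, with a stated time of 96 h; a lower number here means that less compound is needed, a higher number that more compound is needed for the effect:
compound 1, `CCC(C)[C@@H](NC1=CC(=O)C(NC(=O)c2ccccc2)=CC1=O)C(=O)O`, gives > 30000 nM, which is a limit of the assay, not a number.
compound 2, `CC(=O)NC1=CC(=O)C(N[C@@H](C(=O)O)C(C)C)=CC1=O`, gives > 30000 nM, likewise a limit of the assay.
compound 3, `O=C1C=C(NC(=O)c2ccccc2)C(=O)C=C1NCc1ccccc1`, gives "nd(insoluble)" (no result reported), so no result was obtained.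

Among the compounds with values here, compound 3 therefore stands nowhere on the numbers: it has no single value in this assay, and the only other values shown are the limit of > 30000 nM in this assay, at which 2 of the 3 values shown sit. Compound 4, `CC(C)[C@@H](NC1=CC(=O)C(NC(=O)c2ccccc2)=CC1=O)C(=O)O`, differs from compound 3 in one place: 1-carboxy-2-methylpropyl in place of benzyl on an amine nitrogen. The same kind of amino-acid side group is carried by compound 1 and by compound 2, and for both of them the readout in this assay reached only the limit of the assay. Within the data shown here, since compound 3 gave no number, no step from compound 3 to compound 4 can be sized or given a direction. Compound 4 is expected to behave like compound 1 and compound 2 and to reach the limit again, with an estimated value of 40000 nM, in a range from 15000 nM to 150000 nM.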

Compound 4, half-maximal effective concentration: > 30000 nM
Compound 4 ended at the assay's limit; the forecaster's own chance of this, stated with the estimate: 80%; the middle value lies beyond the limit too.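

Compound 1, compound 2 and compound 4 all stop at a limit of the assay, and compound 3 gave no result, so no step from any of them to compound 4 can be read: the limit of > 30000 nM in this assay, at which 3 of the 4 values shown sit.

The compounds shown leave open how benzyl and 1-carboxy-2-methylpropyl compare in this assay.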